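A few compounds are considered here, and "the series" means these few. Any claim that something is new, unique, unknown or untested is made for them only; others in the source may bear on it.

Compound 1 `CC(C)n1c(SCc2ccccc2Cl)nc2cc(NC(=O)C3CC3)ccc21` gives > 10000 nM, a limit of the assay. Compound 2 `COc1ccc([N+](=O)[O-])cc1CSc1nc2cc(NC(=O)OC(C)(C)C)ccc2n1C(C)C` gives 710 nM.

Both were tested in an assay on isolated protein for inhibition of Gonadotropin-releasing hormone receptor (Rattus norvegicus); on this read-out lower numbers stand for stronger inhibition and higher numbers for weaker inhibition. Compound 2 carries the only number shown; the value of compound 1 is only a limit, namely (the limit of > 10000 nM in this assay, at which 1 of the 2 values shown sits). Compound 3 `COc1ccc([N+](=O)[O-])cc1CSc1nc2cc(NC(=O)NC(C)C)ccc2n1C(C)C` differs from compound 2 by isopropylamino in place of tert-butoxy on a carbonyl carbon. Going by the values given here, no measured pair shows this change, so its direction is unknown. The step is expected to be a 1.1-fold higher number from compound 2 to compound 3 (0.05 log units; within the scatter), within the usual scatter. Compound 3 is estimated at 800 nM, between 200 nM and 4000 nM.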

Compound 3, half-maximal inhibitory concentration: 280 nM
The estimate for compound 3 lay 2.9-fold (0.46 log units) above the measured number; measured number inside the range.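

Putting isopropylamino in place of tert-butoxy on a carbonyl carbon gives a 2.5-fold lower number from compound 2 to compound 3 (0.40 log units; beyond the scatter) in this assay, so the group held at this position does affect the read-out. The entering group brings a hydrogen-bond donor that the leaving group lacks, and it is also one heavy atom smaller. Nothing measured here shows which of these differences, if either, accounts for the step.

Still open, from the compounds shown here alone, is how a smaller methylamino or a ring amine such as morpholine on the same carbonyl carbon would read. Also open, going by these compounds, is whether the step holds when other parts of the shared core change.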